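Indazole in Place of Indole on the Amide Carbonyl

The source may report more compounds than this note shows. Statements on the series, on what has been measured and on what is new or still open speak of the compounds shown alone.

Measured compounds and their values:
Compound 1, `O=C(c1cc2ccccc2[nH]1)N1CCc2nc(COc3ccccc3)oc2C1`: 40%
Compound 2, `O=C(c1c[nH]c2ccccc12)N1CCc2nc(COc3ccccc3)oc2C1`: 71%

Both compounds share one core and were tested in a functional assay on HEK293 cells for positive allosteric modulation of metabotropic glutamate receptor 5 (Homo sapiens), read by calcium flux; a higher number here means a larger maximal response, a lower number a smaller maximal response. In this assay compound 2 gives 71%, the higher of the two numbers. Compound 1 gives 40%. For the measured compounds named here, the only measured step is a number 31 percentage points higher from compound 1 to compound 2 (beyond the scatter); it comes from 1H-indol-3-yl in place of 1H-indol-2-yl on a carbonyl carbon, so a small rearrangement at this position already changes the maximal response a great deal.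

Compound 3, `O=C(c1n[nH]c2ccccc12)N1CCc2nc(COc3ccccc3)oc2C1`, keeps the attachment at the same position but alters the ring that is attached: 1H-indazol-3-yl in place of 1H-indol-3-yl on a carbonyl carbon. Going by the values given here, no measured step covers this exchange. Among the compounds with values here, the one measured step shows only that this part of the molecule matters; it gives no direction for a ring exchange. Compound 3 is therefore expected to stay near compound 2, with a wide range: an estimated 62%, between 30% and 90%, which means an expected step of a number 9 percentage points lower from compound 2 to compound 3 (within the scatter).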

Compound 3, largest response reached (reported as percent of maximum), in percent of the reference or control that the assay uses: 68%
Beside the measured number, compound 3's estimate is 6 percentage points below it; low and high end bracket the measured number.
By their numbers in this assay, from the lowest: compound 1; then compounds 3 and 2 (each within the scatter of the next).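

Exchanging 1H-indol-3-yl for 1H-indazol-3-yl on the carbonyl carbon gives a number 3 percentage points lower from compound 2 to compound 3 (within the scatter) in this assay and so leaves the maximal response effectively unchanged, even though the entering group brings a second ring nitrogen and one hydrogen-bond acceptor. Compared with the 1H-indol-2-yl group, the new group gives a number 28 percentage points higher from compound 1 to compound 3 (beyond the scatter) and so keeps most of the gain seen with 1H-indol-3-yl. Across these three compounds, then, the attachment named in the group (3-yl or 2-yl) goes with a large difference in response, while the change of ring atom does not, and no compound here goes against this. Nothing available explains why the added ring nitrogen makes so little difference.

Still open, as far as these compounds go, is whether the hydrogen on the ring nitrogen is needed, which a 1-methyl-1H-indazol-3-yl group would test, and whether two fused rings are needed at all, which a plain phenyl group would test. From the compounds shown here alone, the shared core is also identical in all three compounds, so the effect of a change there, such as a fluorine on its phenoxy ring, remains unknown.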